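The source may hold more compounds than are shown below. What is called first, only, known or untested is meant among the compounds shown, and "the series" means these compounds.

Three compounds that share one core have been examined in a functional assay on Ehrlich cells (Mus musculus) for cytotoxicity; on this read-out higher numbers stand for weaker inhibition and lower numbers for stronger inhibition. Compound 1 `COc1cc(N2C(N)=C(C#N)C(/C=C/c3ccccc3)C3=C2CC(C)(C)CC3=O)cc(OC)c1OC` is reported as "not active" (no number reported) in this assay, and no number is given for it. Compound 2 `COc1cc(N2C(N)=C(C#N)C(c3c(OC)ccc4ccccc34)C3=C2CC(C)(C)CC3=O)cc(OC)c1OC` is likewise reported as "not active" (no number reported) in this assay, again without a number. For the measured compounds named here, compound 3 `COc1cc(N2C(N)=C(C#N)C(c3ccc(Cl)cc3Cl)C3=C2CC(C)(C)CC3=O)cc(OC)c1OC` gives 94700 nM in this assay, the only number among the three, so it stands alone: it can be said only that compound 3 returned a value where compound 1 and compound 2 did not.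

Compound 4 `COc1cc(N2C(N)=C(C#N)C(c3ccccc3Cl)C3=C2CC(C)(C)CC3=O)cc(OC)c1OC` has not yet been measured. It differs from compound 3 by hydrogen in place of chloro on an aromatic carbon. Going by the values given here, no step between measured compounds is available to guide the expectation. Since compound 3 sits at 94700 nM and two of its three relatives returned no number at all, the step is expected to be small, a 1.6-fold higher number from compound 3 to compound 4 (0.20 log units; within the scatter), and if anything to run toward weaker inhibition rather than stronger. Compound 4 is therefore estimated at 150000 nM in this assay, within a range from 50000 nM to 500000 nM.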

Compound 4, half-maximal inhibitory concentration: "not active" (no number reported)
For compound 4 the study gives words and no number; the estimate stays without a comparison.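

Compound 4 is reported in words only in this assay, so no step can be read between compound 3 and compound 4. Nothing shown here bears on the cause of this result. The compounds shown leave open what number, if any, the change from 2,4-dichlorophenyl to 2-chlorophenyl would give.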